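A few compounds are considered here, and "the series" means these few. Any claim that something is new, unique, unknown or untested is made for them only; others in the source may bear on it.

Values measured so far in a functional assay on KB cells (Homo sapiens) for inhibition, with a stated time of 72 h (on this read-out lower numbers stand for stronger inhibition and higher numbers for weaker inhibition), are these:
Compound 1 `COc1ccc(S(=O)(=O)N2CCc3cccc(-c4ccc(F)nc4)c32)cc1` gives 143 nM
Compound 2 `COc1ccc(S(=O)(=O)N2CCc3cccc(-c4ccco4)c32)cc1` gives 82 nM
Compound 3 `COc1ccc(S(=O)(=O)N2CCc3cccc(-c4ccc([N+](=O)[O-])cc4)c32)cc1` gives 52.5 nM

Compound 2 lies within the scatter of both others, with a 1.7-fold lower number from compound 1 to compound 2 (0.24 log units; within the scatter) on one side and a 1.6-fold lower number from compound 2 to compound 3 (0.19 log units; within the scatter) on the other, while only a 2.7-fold lower number from compound 1 to compound 3 (0.44 log units; beyond the scatter) goes beyond it. Compound 4 `COc1ccc(S(=O)(=O)N2CCc3cccc(-c4ccncc4)c32)cc1` has pyridin-4-yl in place of furan-2-yl on an aromatic carbon on the shared core. Among the measured compounds shown here, no measured step makes this exact exchange. For the measured compounds named here, both steps touching compound 2 are small, and compound 1, the only measured compound with a pyridinyl group, gives 143 nM in this assay here. A small move to a higher number is therefore expected, probably not beyond the scatter. The estimated change is a 1.3-fold higher number from compound 2 to compound 4 (0.13 log units; within the scatter) in this read-out. In this assay compound 4 is estimated at 110 nM (expected range 40 nM to 300 nM).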

Compound 4, half-maximal inhibitory concentration: 96 nM
Compound 4: the middle estimate sits 1.1-fold (0.06 log units) above what was measured, within the range that was stated.
By their numbers in this assay, from the lowest: compounds 3, 2, 4 and 1 (each within the scatter of the next, the first and the last beyond it).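

In this assay the pyridin-4-yl group stays within the scatter of every earlier group at this aromatic carbon, giving a 1.2-fold higher number from compound 2 to compound 4 (0.07 log units; within the scatter) and a 1.8-fold higher number from compound 3 to compound 4 (0.26 log units; within the scatter) and also a 1.5-fold lower number from compound 1 to compound 4 (0.17 log units; within the scatter) in the same read-out. Furan-2-yl can thus give way to this six-membered aromatic ring without a readable change, and among the four groups only compound 1 and compound 3 stand apart. No measured evidence bears on this result. The compounds shown leave open whether a non-aromatic group on this carbon, such as an aliphatic amine, a carboxylic acid or a longer alkyl chain, would move the number beyond this band.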